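This account rests on a few compounds, and the source may have more. Where it says the series, first, only, none or still open, it means among the compounds named here.

In a functional assay on P388 cells (Mus musculus) for cytotoxicity (a lower number here means a stronger inhibitor, a higher number a weaker inhibitor), compound 1 (`CCC[C@@H]1NC(=O)[C@@H](C)NC(=O)[C@@H]2Cc3ccc(OC)c(c3)Oc3ccc(cc3)C[C@@H](C(=O)N2C)N(C)C(=O)[C@H](C)NC(=O)[C@H](Cc2ccc(OC)cc2)N(C)C1=O`) gives 13.8 nM and compound 2 (`COc1ccc(C[C@H]2C(=O)N[C@@H](C)C(=O)N(C)[C@H]3Cc4ccc(cc4)Oc4cc(ccc4OC)C[C@@H](C(=O)N[C@H](C)C(=O)N[C@@H](CC(=O)O)C(=O)N2C)N(C)C3=O)cc1`) gives 1200 nM, the higher of the two numbers. For the measured compounds named here, only one measured step bears on what follows: an 87-fold higher number from compound 1 to compound 2 (1.94 log units; beyond the scatter), a large step beyond the scatter, with carboxy in place of ethyl on a saturated chain carbon bound to a saturated ring carbon. Compound 3 (`C=C[C@@H]1NC(=O)[C@@H](C)NC(=O)[C@@H]2Cc3ccc(OC)c(c3)Oc3ccc(cc3)C[C@@H](C(=O)N2C)N(C)C(=O)[C@H](C)NC(=O)[C@H](Cc2ccc(OC)cc2)N(C)C1=O`) departs from compound 2 by vinyl in place of carboxymethyl on a saturated ring carbon, which is vinyl in place of carboxymethyl on a saturated ring carbon. The carboxy group is gone, as it is in compound 1 at 13.8 nM, so most of that large step is expected to run in reverse, towards a lower number. Vinyl itself remains unmeasured, and a single step is thin support. The expected change is a 40-fold lower number from compound 2 to compound 3 (1.60 log units; beyond the scatter). The estimate for compound 3 is 30 nM, with an expected range from 8 nM to 120 nM.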

Compound 3, half-maximal inhibitory concentration: 25.7 nM
Beside the measured number, compound 3's estimate is 1.2-fold (0.07 log units) above it; the measured number falls inside the stated range.
By their numbers in this assay, from the lowest: compounds 1 and 3 (each within the scatter of the next); then compound 2.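

In this assay, the large step back, a 47-fold lower number from compound 2 to compound 3 (1.67 log units; beyond the scatter), shows that the high number of compound 2 does not depend on propyl being the replacement for carboxymethyl at this saturated ring carbon, since vinyl also brings the number down. Vinyl and propyl are not told apart at this position: a 1.9-fold higher number from compound 1 to compound 3 (0.27 log units; within the scatter) lies within the scatter, so the double bond in vinyl shows no measurable effect here. Nothing shown gives a measured reason why compound 2 stands apart from the other two.

Going by these compounds, it remains open whether an aminomethyl or hydroxymethyl group, or the methyl ester of the carboxymethyl group, would stay with compounds 1 and 3 or move towards compound 2. On these data alone, how a chain longer than propyl would behave at this carbon is also open.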